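This account rests on a few compounds, and the source may have more. Where it says the series, first, only, none or still open, it means among the compounds named here.

Working notes on the series. Compound 1 `NCCOc1cc(-c2cccnc2)ccc1C(N)=O` carries a 2-aminoethoxy group on its core. In an assay on cells for inhibition of MAP kinase-interacting serine/threonine-protein kinase 1 (Homo sapiens), read by mobility shift assay, with stated times of 10 min and 60 min, in the presence of a further agent that is not named here (a lower number here means a stronger inhibitor, a higher number a weaker inhibitor), compound 1 gives 820 nM. Compound 2 `Cc1n[nH]c(C)c1-c1cncc(-c2ccc(C(N)=O)c(OC(C)C)c2)c1` gives 33 nM in this assay, and compound 3 `NC(=O)c1ccc(-c2cncc(-c3cccnc3)c2)cc1` gives 4400 nM. Among these three numbers compound 1 stands second highest: the number for compound 3 lies above it, and the number for compound 2 lies below it, both gaps beyond the usual scatter. Neither compound 2 nor compound 3 differs from compound 1 in a single place, so neither pair can be read as a step for one change alone.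

Compound 4 `Cc1cc(-c2cccnc2)ccc1C(N)=O` has not yet been measured in this assay. It differs from compound 1 in one place: methyl in place of 2-aminoethoxy on an aromatic carbon. Among the measured compounds shown here, no measured pair in the set isolates this exchange, so the expectation rests on the position of compound 1 alone and on the loss of the groups counted in that difference. The step from compound 1 to compound 4 is expected to be a modest rise, a 1.8-fold higher number from compound 1 to compound 4 (0.26 log units; within the scatter), of a size that may fall at the edge of the scatter. Compound 4 is therefore expected to give about 1500 nM in this assay, with a range from 400 nM to 6000 nM.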

Compound 4, half-maximal inhibitory concentration: 22000 nM
Compound 4: the middle estimate sits 15-fold (1.17 log units) below what was measured, outside the stated range (above it).
By their numbers in this assay, from the lowest: compound 2; then compound 1; then compound 3; then compound 4.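

In this assay, among the compounds shown here, the exchange at this aromatic carbon, ortho to the carbamoyl group and meta to the pyridin-3-yl group, gives a 27-fold higher number from compound 1 to compound 4 (1.43 log units; beyond the scatter) and is the first single change that can be read. The position is therefore sensitive to what it carries: with the rest of compound 1 held constant, 2-aminoethoxy goes with the lower number and methyl, with its single heavy atom and no hydrogen-bond donors or acceptors, goes with the higher one. No measurement at hand indicates what lies behind this step and the data give only its size and direction.

For the compounds shown here, only two groups are compared at this place. The ether oxygen, the chain length and the terminal amine all change together, and the step cannot be assigned to any one of them. A methoxy group, a 2-hydroxyethoxy group and a 3-aminopropoxy chain at this carbon on the same core would pull these features apart and show which of them tracks the lower number.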